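From ethoxy to 1,2-dihydroxyethyl on compound 1

This account rests on a few compounds, and the source may have more. Where it says the series, first, only, none or still open, it means among the compounds named here.

Among the compounds with values here, in a physicochemical assay for lipophilicity, at pH 7.4 (on this read-out higher numbers stand for higher lipophilicity and lower numbers for lower lipophilicity), compound 1 `CCOc1ccc2c(c1)C(c1cnn(C)c1)=CN(C)C(=O)[C@@H]2C` gives 4.1, the highest number of the three measured so far. Compound 2 `CCOc1ccc2c(c1)C(c1cn[nH]c1)=CN(C)C(=O)[C@@H]2C` gives 3.4, and compound 3 `CCOc1ccc2c(c1)C(c1c[nH]cn1)=CN(C)C(=O)[C@@H]2C` gives 2.7. Compound 4 `C[C@H]1C(=O)N(C)C=C(c2cnn(C)c2)c2cc([C@H](O)CO)ccc21` has not been measured yet. It keeps the core of compound 1 but swaps one group, with 1,2-dihydroxyethyl in place of ethoxy on an aromatic carbon. Within the data shown here, no measured step touches that place, so the guidance is only indirect. Hydrogen in place of methyl on an aromatic nitrogen gave a number 0.70 log units lower from compound 1 to compound 2 (beyond the scatter), and 1H-imidazol-4-yl in place of 1-methyl-1H-pyrazol-4-yl gave a number 1.40 log units lower from compound 1 to compound 3 (beyond the scatter). Both steps went downward, and here a whole group is exchanged, with hydrogen-bond donors entering where none leave. Going by the larger step, a number 1.40 log units lower from compound 1 to compound 3 (beyond the scatter), a large downward move is expected here as well. The expected change is a number 1.50 log units lower from compound 1 to compound 4 (beyond the scatter). For compound 4 the estimate is 2.6, with an expected range from 2 to 3.2.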

Compound 4, distribution coefficient: 1.3
Compound 4: the middle estimate sits 1.30 log units above what was measured, and the stated range ends above it.
By their numbers in this assay, from the lowest: compound 4; then compound 3; then compound 2; then compound 1.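

In this assay, exchanging ethoxy for 1,2-dihydroxyethyl on the aromatic carbon gives a number 2.80 log units lower from compound 1 to compound 4 (beyond the scatter) and so exceeds the largest earlier step, a number 1.40 log units lower from compound 1 to compound 3 (beyond the scatter). This shows that the read-out responds strongly at this place on the ring, which compound 2 and compound 3 left unchanged, and that here the change can be larger than those made at the double-bonded ring carbon. The entering group has 2 hydrogen-bond donors and ethoxy has 0, but no measurement on hand explains the size of this drop.

The compounds shown leave open how 2-hydroxyethyl, with its single hydroxyl group, an amine or a carboxylic acid would read out on this aromatic carbon. They also leave open whether the same exchange would give a similar step with the groups of compound 2 or compound 3 in place.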